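Replacing the group on the aromatic ring of compound 3

This account rests on a few compounds, and the source may have more. Where it says the series, first, only, none or still open, it means among the compounds named here.

In an ADME assay (liver) for metabolic stability, with Liver microsome (Rattus norvegicus) as the target, using microsomes and NADPH, with a stated time of 30 min (on this read-out lower numbers stand for slow clearance and higher numbers for fast clearance), compound 1 `CC#C[C@H]1CN(S(=O)(=O)c2ccc(N)nc2)CCN1c1ccccc1` is reported only as a limit, > 399 mL.min-1.g-1. Compound 2 `C#CCC(O)(c1ccc(N2CCN(S(=O)(=O)c3ccc(N)nc3)C[C@@H]2C#CC)cc1)C(F)(F)F` gives 59 mL.min-1.g-1 and compound 3 `CC#CCC(O)(c1ccc(N2CCN(S(=O)(=O)c3ccc(N)nc3)C[C@@H]2C#CC)cc1)C(F)(F)F` gives 115 mL.min-1.g-1, and a 1.9-fold higher number from compound 2 to compound 3 (0.29 log units; within the scatter) leaves these two within the scatter of each other. Compound 4 `CC#C[C@H]1CN(S(=O)(=O)c2ccc(N)nc2)CCN1c1ccc(S(C)(=N)=O)cc1` keeps a group on the same aromatic carbon, but a different one: a group of 4 heavy atoms (1 carbon, 1 nitrogen, 1 oxygen, 1 sulfur; no ring) in place of a group of 10 heavy atoms (6 carbon, 1 oxygen, 3 fluorine; no ring), on an aromatic carbon. Among the measured compounds shown here, no measured step swaps one such group for another. The closest guides are an at least 6.7-fold lower number from compound 1 to compound 2 (0.83 log units; beyond the scatter) and an at least 3.4-fold lower number from compound 1 to compound 3 (0.54 log units; beyond the scatter), each of which put a group on that carbon where compound 1 has only hydrogen. The expected change is small, a 1.6-fold lower number from compound 3 to compound 4 (0.22 log units; within the scatter), with no shift beyond the scatter. Compound 4 is therefore estimated at 70 mL.min-1.g-1, with an expected range from 25 mL.min-1.g-1 to 200 mL.min-1.g-1.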

Compound 4, intrinsic clearance in microsomes: < 14 mL.min-1.g-1
Compound 4 was reported as a limit; the forecaster's own chance of this, stated with the estimate: 5%; middle value at least 5.0-fold (0.69 log units) from the limit.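

In this assay, among the compounds shown here, the position on the aromatic carbon para to a large group proves more sensitive than the earlier compounds showed, and the group of 4 heavy atoms gives clearly lower numbers than either larger group (an at least 8.2-fold lower number from compound 3 to compound 4 (0.91 log units; beyond the scatter); an at least 4.2-fold lower number from compound 2 to compound 4 (0.62 log units; beyond the scatter)). Compared with hydrogen on that carbon, the change is large (an at least 28-fold lower number from compound 1 to compound 4 (1.45 log units; beyond the scatter)), so a low number here does not need the long fluorinated chain. Compound 4 is reported only as a limit: the limit of < 14 mL.min-1.g-1 in this assay, at which 1 of the 4 values shown sits.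

On these data alone, whether a methyl sulfone or a carboxylic acid on the same carbon would also give a low number remains open.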